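Cyclobutylmethyl Replaces Branched Alkyl on the Amide Nitrogen

The source may report more compounds than this note shows. Statements on the series, on what has been measured and on what is new or still open speak of the compounds shown alone.

Compound 1 `C[C@@H](NC(=O)c1ccc(C#Cc2ccc(F)cc2F)cn1)C(C)(C)O` gives 38.2% in an ADME assay on HEK293 cells for agonist activity at metabotropic glutamate receptor 5 (Rattus norvegicus), read by fluorescence and calcium flux; on this read-out higher numbers stand for larger maximal responses and lower numbers for smaller maximal responses
Compound 2 `CC(C)[C@H](C)NC(=O)c1ccc(C#Cc2cccc(F)c2)cn1` gives 13.1% in this assay

Going by the values given here, compound 2 stands lowest of the two measured compounds; its nearest neighbour, compound 1, lies beyond the scatter above it, but the two differ in more than one place, so no single step can be drawn between them. Compound 3 `O=C(NCC1CCC1)c1ccc(C#Cc2cccc(F)c2)cn1` is not yet measured. It differs from compound 2 in one place: cyclobutylmethyl in place of 1,2-dimethylpropyl on an amide-type nitrogen. The group that leaves and the group that enters are alike in count of heavy atoms, yet the one is a branched chain and the other carries a four-membered ring. Among the compounds with values here, with only two measured compounds, and no step between them that isolates the amide substituent, the data give no direction for this change. The step from compound 2 to compound 3 in this assay is expected to be small, likely within the scatter, a number 4.9 percentage points higher from compound 2 to compound 3 (within the scatter). Compound 3 is expected to give 18%, between 5% and 40%.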

Compound 3, largest response reached (reported as efficacy), in percent of the reference or control that the assay uses: 4.7%
Estimate against measurement, compound 3: 13.3 percentage points above; measured number outside the range, below it.
By their numbers in this assay, from the lowest: compounds 3 and 2 (each within the scatter of the next); then compound 1.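

In this assay the exchange of 1,2-dimethylpropyl for cyclobutylmethyl on the amide-type nitrogen gives a number 8.4 percentage points lower from compound 2 to compound 3 (within the scatter) and so stays inside the usual variation between repeats. Going by these compounds alone, for this pair, then, replacing the branched chain and its defined stereocentre with a four-membered ring of the same heavy-atom count does not separate the two compounds on this read-out, the first information on this position from a single-place change. No accompanying measurement bears on this result, so the data offer no explanation for it.

From the compounds shown here alone, whether a longer chain such as n-hexyl would behave in the same way remains open. So does the effect of placing an amine or a carboxylic acid on the substituent at this nitrogen.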